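The source may hold more compounds than are shown below. What is called first, only, known or untested is meant among the compounds shown, and "the series" means these compounds.

Compound 1 `COC(=O)/C=C/C1=CC[C@H]2C(C)(C)CCC[C@]2(C)[C@H]1C=O` gives 24000 nM
Compound 2 `CCOC(=O)/C=C/C1=CC[C@H]2C(C)(C)CCC[C@]2(C)[C@H]1C=O` gives 29000 nM
Compound 3 `CCOC(=O)/C(C)=C/C1=CC[C@H]2C(C)(C)CCC[C@]2(C)[C@H]1C=O` gives 28000 nM

All three values come from a functional assay on Hs 683 cells (Homo sapiens) for inhibition, read by MTT assay, with a stated time of 72 h; on this read-out higher numbers stand for weaker inhibition of growth and lower numbers for stronger inhibition of growth. Compound 2, at 29000 nM, lies within the scatter of both other compounds, so the three form a single group on these numbers and none can be ranked above another.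

The next compound to be tested is compound 4 `CC(C)(C)OC(=O)/C=C/C1=CC[C@H]2C(C)(C)CCC[C@]2(C)[C@H]1C=O`. It differs from compound 2 by one change, (tert-butyl in place of ethyl on an oxygen next to a carbonyl group), which puts tert-butyl in place of ethyl on an oxygen next to a carbonyl group.

Going by the values given here, one measured step bears directly on this change. It is a 1.2-fold higher number from compound 1 to compound 2 (0.08 log units; within the scatter), where methyl replaces hydrogen on a saturated chain carbon bound to an oxygen next to a carbonyl group. That step is small and stays within the scatter. However, it is only a single step, and no measured compound carries tert-butyl on that oxygen, so the evidence is indirect and the range should stay fairly wide. On this basis, no change beyond the scatter is expected in this assay, and the expected result is a 1.0-fold lower number from compound 2 to compound 4 (0.02 log units; within the scatter). For compound 4 the estimated value is 28000 nM, with an expected range from 14000 nM to 55000 nM.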

Compound 4, concentration for 50% growth inhibition: 29000 nM
Beside the measured number, compound 4's estimate is 1.0-fold (0.02 log units) below it, within the range that was stated.
By their numbers in this assay, from the lowest: compounds 1, 3, 2 and 4 (each within the scatter of the next).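

In this assay, going by these compounds alone, the earlier compounds showed only the small move from methyl to ethyl on an oxygen next to a carbonyl group. Compound 4 tests a much larger group at this place, with tert-butyl and its four carbons entering in place of ethyl and its two, and the result is no change at the digits printed from compound 2 to compound 4 (within the scatter); set against the smallest group in the series, the same place gives a 1.2-fold higher number from compound 1 to compound 4 (0.08 log units; within the scatter). Both steps stay within the scatter, so methyl, ethyl and tert-butyl on this oxygen form one group on these numbers, and no measurement at hand explains why the size of this group leaves the read-out unmoved.

The compounds shown leave open whether this holds for groups of another kind on that oxygen, such as a benzyl group with its ring, a much longer chain like octyl, or simply hydrogen, which would give the free carboxylic acid. They also leave open whether any change at this place can move the number at all, or whether growth inhibition in these cells depends on other parts of the molecule.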